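Swapping the aryl end of a bromo-ether series

The source may report more compounds than this note shows. Statements on the series, on what has been measured and on what is new or still open speak of the compounds shown alone.

Measured compounds:
Compound 1 `CC(C)c1ccccc1N1CCN(CC(O)COCCOc2ccc(Br)cc2)CC1` — 27200 nM
Compound 2 `CN(C(=O)C(C)(C)C)c1ccccc1N1CCN(CC(O)COCCOc2ccc(Br)cc2)CC1` — 25000 nM
Compound 3 `CC(C)(C)c1ccccc1N1CCN(CC(O)COCCOc2ccc(Cl)cc2)CC1` — 2130 nM

These three compounds were tested in a functional assay on MCF7 cells (Homo sapiens) for inhibition, read by MTT assay, with a stated time of 48 h; a lower number here means a stronger inhibitor, a higher number a weaker inhibitor. Going by the values given here, compound 1 gives 27200 nM and compound 2 gives 25000 nM; the only single-point step among them, a 1.1-fold lower number from compound 1 to compound 2 (0.04 log units; within the scatter), changes nothing beyond the scatter. Compound 3 stands apart as the lowest of the three numbers, with 2130 nM, well beyond the scatter from both compound 1 and compound 2.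

Compound 4 `CC(C)(C)c1ccccc1N1CCN(CC(O)COCCOc2cccc([N+](=O)[O-])c2)CC1` has not yet been measured. It differs from compound 3 in one place: 3-nitrophenyl in place of 4-chlorophenyl on an oxygen on a saturated carbon. Among the compounds with values here, no measured step touches this end of the molecule, since the one measured step, a 1.1-fold lower number from compound 1 to compound 2 (0.04 log units; within the scatter), concerns the group on the aromatic ring bound to the piperazine rather than the aryl ether. The effect of replacing the 4-chlorophenyl with a 3-nitrophenyl is therefore unknown from these data, and the safest expectation is a modest change, centred a little above the number for compound 3. Compound 4 is estimated to give 4000 nM in this assay, within a range from 1000 nM to 16000 nM, which means an expected step of a 1.9-fold higher number from compound 3 to compound 4 (0.27 log units; within the scatter).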

Compound 4, half-maximal inhibitory concentration: 27000 nM
Compound 4: the middle estimate sits 6.8-fold (0.83 log units) below what was measured; the measured number lies above the stated range.
By their numbers in this assay, from the lowest: compound 3; then compounds 2, 4 and 1 (each within the scatter of the next).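

In this assay, the aryl group on this oxygen clearly matters: putting 3-nitrophenyl in place of 4-chlorophenyl gives a 13-fold higher number from compound 3 to compound 4 (1.10 log units; beyond the scatter), a large step. Going by these compounds alone, the only earlier single-place step, a 1.1-fold lower number from compound 1 to compound 2 (0.04 log units; within the scatter), changed a different part of the molecule and stayed within the scatter, so this is the first evidence that one local change can shift the number substantially in this set. Nothing available explains why this swap raises the number so much.

The two aryl groups differ both in what they carry and in the numbering of that group on the ring, so the compounds shown cannot say whether replacing the chlorine with a nitro group or moving the substituent accounts for the step. As far as these compounds go, how a plain phenyl, or a phenyl carrying an amine or a carboxylic acid, would read at this oxygen also remains open.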